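Moving the iodine from 3-iodophenyl to 4-iodophenyl

The compounds below may be only part of what the source reports. "The series", "measured", "known", "first", "only" and "open" are said of these compounds alone.

In a functional assay on SK-MEL-28 cells (Homo sapiens) for cytotoxicity, read by CCK-8 assay, with a stated time of 24 h (a higher number here means a weaker inhibitor, a lower number a stronger inhibitor), compound 1 (`COc1ccccc1Oc1c(N)nc(-c2ccc(Br)cc2)nc1Cl`) gives 14 nM, while compound 2 (`COc1ccccc1Oc1c(N)nc(-c2cccc(I)c2)nc1Cl`) gives 4660 nM. Compound 2 therefore has the higher of the two numbers and is the weaker inhibitor of the pair. Compound 3 (`COc1ccccc1Oc1c(N)nc(-c2ccc(I)cc2)nc1Cl`) has not yet been measured. It differs from compound 2 in one place: 4-iodophenyl in place of 3-iodophenyl on an aromatic carbon. The two have the same atoms, joined differently, so only the place of the iodine on the phenyl ring changes.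

Within the data shown here, one measured step bears on this change: a 330-fold higher number from compound 1 to compound 2 (2.52 log units; beyond the scatter). That large step swapped the halogen and moved it at the same time, so it cannot show how much of the change comes from moving it alone. Still, compound 3 has the 4-iodophenyl group, which matches the 4-bromophenyl group of compound 1 at 14 nM more closely than the 3-iodophenyl group does. A large move toward a lower number is therefore expected, an estimated 120-fold lower number from compound 2 to compound 3 (2.07 log units; beyond the scatter). Among the measured compounds shown here, no measured step shows the effect of iodine in place of bromine, so the range stays wide. For compound 3 the estimated value is 40 nM, with an expected range from 8 nM to 300 nM.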

Compound 3, half-maximal inhibitory concentration: 1250 nM
The estimate for compound 3 lay 31-fold (1.49 log units) below the measured number, and the stated range ends below it.
By their numbers in this assay, from the lowest: compound 1; then compound 3; then compound 2.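

In this assay, moving only the iodine on the phenyl ring gives a 3.7-fold lower number from compound 2 to compound 3 (0.57 log units; beyond the scatter) and so isolates an effect that the earlier step could not separate: the place of the iodine matters, but this change alone brings only a modest gain. With the halogen kept in the same place on the ring, the change of iodo to bromo can now be read in its own step, and the listed direction gives an 89-fold higher number from compound 1 to compound 3 (1.95 log units; beyond the scatter) as a large difference that leaves compound 3 far from compound 1 even with its iodine in the matching place. The halogen itself therefore matters here as well as its place, and nothing shown gives a reason for either step.

The compounds shown leave open how 3-bromophenyl would compare with 4-bromophenyl, a pair that would test whether moving a bromine changes the number as much as moving an iodine does. They also leave open whether 4-chlorophenyl or 4-methoxyphenyl would give a number closer to that of compound 1 or to that of compound 3.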